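This account rests on a few compounds, and the source may have more. Where it says the series, first, only, none or still open, it means among the compounds named here.

Measured compounds in a toxicity assay on THP-1 cells (Homo sapiens) for inhibition; on this read-out higher numbers stand for lower toxicity in this test and lower numbers for higher toxicity in this test:
compound 1, `COc1ccc(-c2cnc(NC(=O)CCc3ccccc3)n2C)cc1` — compound 1 gives > 100000 nM, a limit of the assay.
compound 2, `COc1ccc(-c2cnc(NC(=O)c3ccno3)n2C)cc1` — compound 2 gives > 100000 nM, a limit of the assay.
compound 3, `COc1ccc(-c2cnc(NC(=O)c3cccc(F)c3)n2C)cc1` — compound 3 gives > 100000 nM, a limit of the assay.

Compound 3 therefore stands at the limit, as do the other two compounds (the limit of > 100000 nM in this assay, at which 3 of the 3 values shown sit). None of the three values is a number, so the steps between them cannot be read: a step that the two limits leave unreadable from compound 1 to compound 3 and a step that the two limits leave unreadable from compound 2 to compound 3, and likewise a step that the two limits leave unreadable from compound 1 to compound 2.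

Compound 4, `COc1ccc(-c2cnc(NC(=O)c3cccc(Br)c3)n2C)cc1`, has not been measured. It differs from compound 3 by bromo in place of fluoro on an aromatic carbon, so that the 3-fluorophenyl of compound 3 becomes a 3-bromophenyl. Among the compounds with values here, no measured step touches an exchange of bromo for fluoro, and the steps that reach compound 3 are unreadable, so nothing in the numbers points to a direction beyond the scatter. Compound 4 is therefore expected to stay at the limit, estimated at 100000 nM with a range from 40000 nM to 300000 nM. The expected step is a number no higher from compound 3 to compound 4 (the limit leaves the size open).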

Compound 4, half-maximal cytotoxic concentration: > 100000 nM
Compound 4 gave a limit, no number; the forecaster's own chance of this, stated with the estimate: 80%; the middle value lies on the limit itself.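

In this assay compound 4 gives > 100000 nM as a limit of the assay, not a number. Its steps from compound 1, compound 2 and compound 3 therefore cannot be read. The compounds shown leave open whether any exchange among them changes the read-out in this assay at all.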